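Shortening the linker in a bis(trifluoromethyl)benzenesulfonamide series

The compounds below may be only part of what the source reports. "The series", "measured", "known", "first", "only" and "open" are said of these compounds alone.

Measured compounds:
compound 1 `O=S(=O)(NCCCNCc1ccccc1Cl)c1cc(C(F)(F)F)cc(C(F)(F)F)c1` — 11000 nM
compound 2 `O=S(=O)(NCCCCNCc1ccc(Br)cc1)c1cc(C(F)(F)F)cc(C(F)(F)F)c1` — 1700 nM
compound 3 `O=S(=O)(NCCCNCc1ccc(C(F)(F)F)cc1)c1cc(C(F)(F)F)cc(C(F)(F)F)c1` — 1700 nM

In a functional assay on BXPC-3 cells (Homo sapiens) for inhibition, read by MTT assay, with a stated time of 72 h (a higher number here means a weaker inhibitor of growth, a lower number a stronger inhibitor of growth), compound 2 stands level with compound 3 at the digits printed, the two together giving the lowest numbers of the three, while compound 1 sits highest, as a 6.5-fold lower number from compound 1 to compound 2 (0.81 log units; beyond the scatter) shows. Compound 4 `O=S(=O)(NCCCNCc1ccc(Br)cc1)c1cc(C(F)(F)F)cc(C(F)(F)F)c1` is not yet measured. It differs from compound 2 by (4-bromobenzyl)amino in place of ((4-bromobenzyl)amino)methyl on a saturated chain carbon, three bonds along the chain from a sulfonamide nitrogen.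

Among the compounds with values here, no measured step isolates this change. The step of a 6.5-fold lower number from compound 1 to compound 2 (0.81 log units; beyond the scatter) contains the same alteration of the linker in the opposite direction, but it is confounded with a change of the benzyl substituent; the step of a 6.5-fold lower number from compound 1 to compound 3 (0.81 log units; beyond the scatter), which alters only the benzyl group, is of the same size. The two steps therefore leave little room for the linker alone, and compound 4 is expected to differ from compound 2 by a step no larger than the scatter, a 1.2-fold higher number from compound 2 to compound 4 (0.07 log units; within the scatter). Compound 4 is estimated at 2000 nM, with a range from 800 nM to 5000 nM.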

Compound 4, concentration for 50% growth inhibition: 1500 nM
Compound 4: the middle estimate sits 1.3-fold (0.12 log units) above what was measured; low and high end bracket the measured number.
By their numbers in this assay, from the lowest: compounds 4, 2 and 3 (each within the scatter of the next); then compound 1.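

In this assay, within the data shown here, the step of a 1.1-fold lower number from compound 2 to compound 4 (0.05 log units; within the scatter) is the first to isolate the linker: with the 4-bromobenzyl group held constant, (4-bromobenzyl)amino in place of ((4-bromobenzyl)amino)methyl on this saturated chain carbon leaves the number within the scatter. On the same chain, the step of a 1.1-fold lower number from compound 3 to compound 4 (0.05 log units; within the scatter) shows that bromo in place of trifluoromethyl on an aromatic carbon also stays within the scatter, whereas the step of a 7.3-fold lower number from compound 1 to compound 4 (0.87 log units; beyond the scatter) lies beyond it and places the larger difference on 4-bromophenyl in place of 2-chlorophenyl. No measurement shown accounts for any of these steps.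

The compounds shown leave open whether the linker stays equally silent with other benzyl groups or with a longer chain such as a pentane linker. They also leave open whether a 4-chlorobenzyl group would match compound 4 or compound 1.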